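Swapping the aryl group on the sulfur of a nucleoside scaffold

This account rests on a few compounds, and the source may have more. Where it says the series, first, only, none or still open, it means among the compounds named here.

Measured so far:
compound 1, `OC[C@H]1O[C@@H](n2cnc3c(SCC4CCCCC4)ncnc32)[C@H](O)[C@@H]1O` — 1550 nM
compound 2, `Cc1ccc(CSc2ncnc3c2ncn3[C@@H]2O[C@H](CO)[C@@H](O)[C@H]2O)cc1` — 457 nM
compound 3, `OC[C@H]1O[C@@H](n2cnc3c(CSc4cccc(I)c4)ncnc32)[C@H](O)[C@@H]1O` — 245 nM

All three share one core and differ only in the group carried on the sulfur. In an assay on isolated protein for binding affinity to Equilibrative nucleoside transporter 1 (Homo sapiens) (on this read-out higher numbers stand for weaker inhibition and lower numbers for stronger inhibition), compound 3 gives the smallest of the three numbers; compound 1 sits furthest away, at a 6.3-fold lower number from compound 1 to compound 3 (0.80 log units; beyond the scatter), while compound 2 lies within the scatter, at a 1.9-fold lower number from compound 2 to compound 3 (0.27 log units; within the scatter).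

Compound 4, `CC(C)(C)c1ccc(SCc2ncnc3c2ncn3[C@@H]2O[C@H](CO)[C@@H](O)[C@H]2O)cc1`, carries 4-(tert-butyl)phenyl in place of 3-iodophenyl on a sulfur. Among the compounds with values here, two measured steps bear on this. Exchanging a ring on the sulfur for a different ring gave a 1.9-fold lower number from compound 2 to compound 3 (0.27 log units; within the scatter), a change inside the scatter; only the move from a non-aromatic to an aromatic ring, a 3.4-fold lower number from compound 1 to compound 2 (0.53 log units; beyond the scatter), went beyond it. Compound 4 keeps an aromatic ring, so no step beyond the scatter is expected in this assay, perhaps a slight rise toward the number of compound 2. Compound 4 is therefore estimated at 350 nM, expected between 120 nM and 1000 nM, which means a step of a 1.4-fold higher number from compound 3 to compound 4 (0.15 log units; within the scatter).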

Compound 4, half-maximal inhibitory concentration: 331000 nM
Estimate against measurement, compound 4: 950-fold (2.98 log units) below, outside the stated range (above it).
By their numbers in this assay, from the lowest: compounds 3 and 2 (each within the scatter of the next); then compound 1; then compound 4.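

In this assay, the group on the sulfur proves far less forgiving than the earlier ring swaps suggested: 4-(tert-butyl)phenyl in place of 3-iodophenyl gives a 1400-fold higher number from compound 3 to compound 4 (3.13 log units; beyond the scatter), whereas the earlier step of a 3.4-fold lower number from compound 1 to compound 2 (0.53 log units; beyond the scatter) was only modest. Both groups carry one six-membered aromatic ring of carbon only and neither has hydrogen-bond donors or acceptors, so an aromatic ring on this sulfur does not by itself secure a low number. Nothing measured here accounts for so large a step.

This change replaces iodine with tert-butyl and also changes the numbered ring place from 3 to 4, and these compounds cannot separate the two. Also open, going by these compounds, is how the number would respond to an amine or a carboxylic acid on that aromatic ring.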